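Nitro removal on the pyrazoline aryl ring of compound 1

A few compounds are considered here, and "the series" means these few. Any claim that something is new, unique, unknown or untested is made for them only; others in the source may bear on it.

Working notes on a short series tested in a functional assay on the whole organism (strain Wistar) for inhibition, with Rattus norvegicus as the target, read by paw edema, with a stated time of 30 min, at a dose of 50 mg/kg by the oral route; a higher number here means more inhibition at the dose given (going by the name of the read-out), a lower number less inhibition. Compound 1 `Cc1ccc(C2=NN(c3ccc([N+](=O)[O-])cc3)C(c3cn(-c4ccccc4)nc3-c3ccc(Cl)c(Cl)c3)C2)cc1` gives 57.4% in this assay. Compound 2 `O=[N+]([O-])c1ccc(N2N=C(c3ccc(Cl)cc3)CC2c2cn(-c3ccccc3)nc2-c2ccc(Cl)c(Cl)c2)cc1` gives 48.9% in this assay. Going by the values given here, the one comparison that exists runs a number 8.5 percentage points lower from compound 1 to compound 2 (within the scatter), which says that the methyl and chloro variants cannot be told apart on these numbers. Compound 1 therefore stands at the top of two numbers, with compound 2 within the scatter of it, so no ordering of the two is claimed.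

Compound 3 `Cc1ccc(C2=NN(c3ccccc3)C(c3cn(-c4ccccc4)nc3-c3ccc(Cl)c(Cl)c3)C2)cc1` differs from compound 1 as follows: hydrogen in place of nitro on an aromatic carbon. Among the compounds with values here, no measured step touches this part of the shared core; the only step on record, from compound 1 to compound 2, concerns the other aryl ring and lies within the scatter. There is thus nothing in the data that points to a change beyond the scatter in this assay, and nothing that rules one out. The estimate is that compound 3 reaches 52%, within 35% to 68%, which means an expected step of a number 5.4 percentage points lower from compound 1 to compound 3 (within the scatter) carried with wide uncertainty.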

Compound 3, a percentage reported as inhibition, in the whole organism at one dose (the size of the read-out at that dose, not a potency): 46.8%
Compound 3: middle estimate off by 5.2 percentage points, on the high side; low and high end bracket the measured number.
By their numbers in this assay, from the lowest: compounds 3, 2 and 1 (each within the scatter of the next, the first and the last beyond it).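

Hydrogen in place of nitro is the first change in the series to give a step beyond the scatter: in this assay the change from 4-nitrophenyl to phenyl gives a number 10.6 percentage points lower from compound 1 to compound 3 (beyond the scatter) and the only earlier step, on the other aryl ring, stayed within it. The place para to a large group on this six-membered aromatic ring therefore does register in the read-out, with more inhibition at the dose given when the nitro group is present, although this rests on one modest step from a single pair at one oral dose. Nothing on hand bears on why the number moves with the loss of the nitro group.

The compounds shown leave open whether the step belongs to the nitro group in particular or whether other groups at this place, such as an amine, a methoxy group or a carboxylic acid, would hold the number of compound 1 or fall to that of compound 3. They also leave open whether the same change would give a similar step with chloro in place of methyl on the other aryl ring.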